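The source may hold more compounds than are shown below. What is called first, only, known or untested is meant among the compounds shown, and "the series" means these compounds.

Compound 1 `CCCc1cc(NC2CCC2)c2cc(NC(=O)/C=C/c3ccc(C(F)(F)F)cc3)ccc2n1` gives 18 nM in an assay on isolated protein for displacement of a labelled ligand from melanin-concentrating hormone receptor 1 (Homo sapiens); on this read-out lower numbers stand for stronger inhibition and higher numbers for weaker inhibition.
Compound 2 `CCCc1cc(N2CCCC2)c2cc(NC(=O)/C=C/c3ccc(C(F)(F)F)cc3)ccc2n1` gives 17 nM in this assay.
Compound 3 `CCCc1cc(N(C)C)c2cc(NC(=O)/C=C/c3ccc(C(F)(F)F)cc3)ccc2n1` gives 43 nM in this assay.

Compound 3 stands highest of the three numbers in this assay: the step of a 2.4-fold higher number from compound 1 to compound 3 (0.38 log units; beyond the scatter) and the step of a 2.5-fold higher number from compound 2 to compound 3 (0.40 log units; beyond the scatter) both lie beyond the scatter, while the step of a 1.1-fold lower number from compound 1 to compound 2 (0.02 log units; within the scatter) does not. Compound 4 `CCCc1cc(OC)c2cc(NC(=O)/C=C/c3ccc(C(F)(F)F)cc3)ccc2n1` has not yet been measured; it differs from compound 3 by methoxy in place of dimethylamino on an aromatic carbon. Going by the values given here, no measured step replaces an amine at this carbon with an ether, so the measured steps bear on the change only indirectly: both steps that arrive at compound 3 replace a ring-bearing amino group with the smaller dimethylamino group and raise the number modestly. Methoxy is smaller again, and the group that enters is an ether rather than an amine. On that basis a further modest rise in this assay is expected, though a step within the scatter cannot be excluded. The step from compound 3 to compound 4 is estimated as a 1.9-fold higher number from compound 3 to compound 4 (0.27 log units; within the scatter). Compound 4 is therefore expected to give about 80 nM in this assay, with a likely range from 25 nM to 250 nM.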

Compound 4, half-maximal inhibitory concentration: 26 nM
Beside the measured number, compound 4's estimate is 3.1-fold (0.49 log units) above it, within the range that was stated.
By their numbers in this assay, from the lowest: compounds 2, 1, 4 and 3 (each within the scatter of the next, the first and the last beyond it).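

In this assay, methoxy in place of dimethylamino on this carbon, opposite the ring nitrogen, gives a 1.7-fold lower number from compound 3 to compound 4 (0.22 log units; within the scatter), and the comparisons with the two ring-bearing amino groups give a 1.5-fold higher number from compound 2 to compound 4 (0.18 log units; within the scatter) and a 1.4-fold higher number from compound 1 to compound 4 (0.16 log units; within the scatter), so the ether cannot be told apart from any of the three amines, and a nitrogen attached at this carbon is not needed for a number in this range. The earlier compounds shown here linked a smaller group to a higher number, but methoxy, with fewer heavy atoms than dimethylamino, shows no further rise, so compound 4 goes against that link. Nothing available here explains why the ether and the amines cannot be separated at this carbon.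

The compounds shown leave open whether a longer ether such as ethoxy, or a hydroxyl group or a single chlorine atom, would also stay in this range at the same carbon. They also leave open whether a primary amine would fall in with the ring-bearing amino groups or with dimethylamino.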